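A few compounds are considered here, and "the series" means these few. Any claim that something is new, unique, unknown or untested is made for them only; others in the source may bear on it.

Going by the values given here, in a functional assay on MDA-MB-231 cells (Homo sapiens) for antiproliferative activity, read by MTT assay, with a stated time of 72 h (on this read-out higher numbers stand for weaker inhibition and lower numbers for stronger inhibition), three compounds on a shared core have numbers so far. Compound 1 (`NC1=NC2(CCOCC2)N(OCCCOc2cccc(Cl)c2Cl)C(N)=N1`) gives 140 nM and compound 2 (`NC1=NC2(CCOCC2)N(OCCCOc2ccccc2Cl)C(N)=N1`) gives 1430 nM in this series. Compound 3 (`NC1=NC2(CCOCC2)N(OCCCOc2ccc(Cl)c(Cl)c2)C(N)=N1`) gives 590 nM and holds the middle place among the three numbers. It lies a 2.4-fold lower number from compound 2 to compound 3 (0.38 log units; beyond the scatter) and a 4.2-fold higher number from compound 1 to compound 3 (0.62 log units; beyond the scatter) in the two steps that reach it.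

Compound 4 (`NC1=NC2(CCOCC2)N(OCCCOc2cccc(Cl)c2)C(N)=N1`) is related to compound 3 by hydrogen in place of chloro on an aromatic carbon and this turns 3,4-dichlorophenyl into 3-chlorophenyl. One measured step makes the same kind of change, hydrogen in place of chloro on an aromatic carbon, and it is large: a 10-fold higher number from compound 1 to compound 2 (1.01 log units; beyond the scatter) in the direction of weaker inhibition. The other two steps show that the arrangement of chloro groups also moves the number, so the large step need not carry over in full. A smaller move in the same direction is therefore expected in this assay for the loss from compound 3. The estimated step is a 2.2-fold higher number from compound 3 to compound 4 (0.34 log units; beyond the scatter) on this read-out. Compound 4 is expected at 1300 nM with an estimated range from 500 nM to 3200 nM in this assay.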

Compound 4, half-maximal inhibitory concentration: 1020 nM
Compound 4: middle estimate off by 1.3-fold (0.11 log units), on the high side, and the stated range covers the measured number.
By their numbers in this assay, from the lowest: compound 1; then compounds 3, 4 and 2 (each within the scatter of the next, the first and the last beyond it).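

In this assay, taking away the chloro group that stands para to a large group and ortho to a chloro group leaves little measurable change, with a 1.7-fold higher number from compound 3 to compound 4 (0.24 log units; within the scatter). The cost of losing a chloro group therefore has no single size in this set, since it depends on the arrangement of chloro groups that it starts from: the same change on two cores in this assay, a 10-fold higher number (1.01 log units; beyond the scatter) from compound 1 to compound 2 and a 1.7-fold higher number (0.24 log units; within the scatter) from compound 3 to compound 4, 5.9-fold (0.77 log units) apart, beyond the scatter of two such steps

The two monochloro compounds are not separated, with a 1.4-fold lower number from compound 2 to compound 4 (0.15 log units; within the scatter), whereas a 7.3-fold higher number from compound 1 to compound 4 (0.86 log units; beyond the scatter) keeps the 2,3-dichlorophenyl compound apart, and compound 1 now stands beyond the scatter from all three others.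

The compounds shown leave open whether a fluoro or methoxy group could stand in for either chloro group of compound 1 on the same ring. They also leave open how a longer chain to the aromatic ring would change the number.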